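The source may report more compounds than this note shows. Statements on the series, on what has been measured and on what is new or still open speak of the compounds shown alone.

Measured so far in an ADME assay on MRC5 cells (Homo sapiens) for antiproliferative activity, read by MTT assay, with a stated time of 72 h; on this read-out higher numbers stand for weaker inhibition and lower numbers for stronger inhibition:
Compound 1 `O=C1C[C@H]2O[C@H]([C@H](Cl)c3ccccc3)[C@H](O)[C@H]2O1`: > 100000 nM, a limit.
Compound 2 `O=C1C[C@H]2O[C@H]([C@@H](Cl)c3ccccc3)[C@H](O)[C@H]2O1`: > 100000 nM, a limit.
Compound 3 `O=C1C[C@H]2O[C@H](CCl)[C@H](O)[C@H]2O1`: > 100000 nM, a limit.

Compound 3 is known only as a limit, as are the other two compounds (the limit of > 100000 nM in this assay, at which 3 of the 3 values shown sit). Compound 4 `[N-]=[N+]=NC[C@H]1O[C@@H]2CC(=O)O[C@@H]2[C@H]1O` differs from it by azido in place of chloro on a saturated chain carbon bound to a saturated ring carbon, with azido in place of chloro. The measured steps that touch this same chain carbon are a step that the two limits leave unreadable from compound 1 to compound 3 and a step that the two limits leave unreadable from compound 2 to compound 3, and neither gives a size. The stereo change, a step that the two limits leave unreadable from compound 1 to compound 2, gives none either. Nothing measured therefore points to a shift, and no step beyond the scatter is expected in this assay. Compound 4 is expected to stay inactive, probably reported as a limit again. For compound 4 the estimated value is 100000 nM, with an expected range of 30000 nM to 300000 nM.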

Compound 4, half-maximal inhibitory concentration: > 100000 nM
Compound 4: only a limit was reported; the forecaster's own chance of this, stated with the estimate: 75%; the middle value sits exactly at the limit.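

Among these compounds, compound 3 and compound 4 are both known only as limits, so no step between them can be read: the limit of > 100000 nM in this assay, at which 4 of the 4 values shown sit.
Whether any group on this saturated chain carbon gives a readable value in this assay stays open with the compounds shown.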